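Triazene amides: chloroacetyl variant of compound 3

The compounds below may be only part of what the source reports. "The series", "measured", "known", "first", "only" and "open" are said of these compounds alone.

Measured so far:
- compound 1, `CC(=O)N(/N=N/c1ccc([N+](=O)[O-])cc1)c1ccc([N+](=O)[O-])cc1`: 63000 nM
- compound 2, `O=C(c1ccccc1C(F)(F)F)N(/N=N/c1ccc([N+](=O)[O-])cc1Br)c1ccc([N+](=O)[O-])cc1Br`: 13300 nM
- compound 3, `O=C(c1ccccc1)N(/N=N/c1ccc([N+](=O)[O-])cc1Cl)c1ccc([N+](=O)[O-])cc1Cl`: 590 nM

In a functional assay on HeLa cells (Homo sapiens) for cytotoxicity, read by MTT assay, with a stated time of 72 h (a lower number here means a stronger inhibitor, a higher number a weaker inhibitor), compound 3 gives the lowest number of the three; compound 2 stands well above it and compound 1 further still, both gaps beyond the scatter. Compound 1 differs from compound 3 in more than one place, so the two values are reported side by side and nothing is taken from them about the acyl group alone; the same holds for compound 2.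

Compound 4, `O=C(CCl)N(/N=N/c1ccc([N+](=O)[O-])cc1Cl)c1ccc([N+](=O)[O-])cc1Cl`, is not yet measured. It differs from compound 3 in one place: chloromethyl in place of phenyl on a carbonyl carbon. Within the data shown here, no measured pair shows this change, so no size or direction of step is known from the data. The expectation is a modest step, not clearly beyond the scatter, with a wide range to either side. The estimated step from compound 3 to compound 4 is a 2.5-fold higher number from compound 3 to compound 4 (0.41 log units; beyond the scatter). Compound 4 is expected to give 1500 nM, with a range from 300 nM to 8000 nM.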

Compound 4, half-maximal inhibitory concentration: 550 nM
For compound 4 the middle estimate is 2.7-fold (0.44 log units) above the measured one; low and high end bracket the measured number.
By their numbers in this assay, from the lowest: compounds 4 and 3 (each within the scatter of the next); then compound 2; then compound 1.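

In this assay, among these compounds, the first matched pair at this position reads a 1.1-fold lower number from compound 3 to compound 4 (0.03 log units; within the scatter). On the carbonyl carbon of this core, phenyl and chloromethyl therefore cannot be told apart, and the six-membered aromatic ring is not needed for a value of this size in this pair. Nothing measured here accounts for the match between the two groups.

Compound 1 and compound 2 each differ from compound 4 in more than one place, so they cannot show whether the match extends to their acyl groups or to other cores. Also open, on these data alone, is how this position responds to groups such as a dimethylamino group, a carboxylic acid or a longer chain such as butyl, and whether the chlorine of chloromethyl matters compared with a plain methyl on the same core.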